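The source may report more compounds than this note shows. Statements on the series, on what has been measured and on what is new or still open speak of the compounds shown alone.

Measured compounds in a functional assay on CHO cells for agonist activity at Alpha-2B adrenergic receptor (Homo sapiens); a lower number here means a smaller maximal response, a higher number a larger maximal response:

Compound 1, `CC(Oc1ccccc1-c1ccccc1O)C1=NCCN1`, gives < 0.3, which is a limit of the assay and not a number.

Compound 2, `Cc1ccccc1-c1ccccc1OC(C)C1=NCCN1`, gives < 0.3, also a limit of the assay and not a number.

Compound 2 therefore stands only at a limit in this assay, with no measured number of its own. Going by the values given here, the single measured step, a step that the two limits leave unreadable from compound 1 to compound 2, cannot be read in size, since both ends sit at the same limit; this is what the limit of < 0.3 in this assay, at which 2 of the 2 values shown sit, shows, with both values at that limit.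

Compound 3, `CC(Oc1ccccc1-c1ccc(O)cc1)C1=NCCN1`, differs from compound 2 in one place: 4-hydroxyphenyl in place of 2-methylphenyl on an aromatic carbon. Among the compounds with values here, this change sits in the same part of the molecule as the change from compound 1 to compound 2, which is the only measured step that bears on it, and that step gave no readable size. No listed compound gives a numbered response in this assay, so there is no basis for expecting compound 3 to rise out of the limit region. Compound 3 is therefore expected to give about 0.2 in this assay, within the range 0.05 to 0.4. The step from compound 2 that this estimate means, a step that the limit leaves unreadable from compound 2 to compound 3, is expected to be small or unreadable, with compound 3 most likely reported again only as a limit.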

Compound 3, intrinsic activity: the largest response reached, as a fraction of the reference agonist's: < 0.3
Compound 3: a limit, no number; the forecaster's own chance of this, stated with the estimate: 70%; the middle value does not contradict the limit.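

In this assay compound 3 gives < 0.3, which is a limit of the assay and not a number. Going by these compounds alone, no step to compound 3, from compound 1 or from compound 2, can be read in size, as all three compounds sit at one limit: the limit of < 0.3 in this assay, at which 3 of the 3 values shown sit. The compounds shown leave open how large the maximal response of each one is, and whether swapping these groups changes it at all.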